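One More Methyl on Compound 3

The source may hold more compounds than are shown below. What is called first, only, known or untested is meant among the compounds shown, and "the series" means these compounds.

In a physicochemical assay for lipophilicity (on this read-out lower numbers stand for lower lipophilicity and higher numbers for higher lipophilicity), compound 3 `COc1c(OC)c(OC(=O)C(C)(C)C)c2cc(C)ccc2c1OC(=O)C(C)(C)C` gives 6.1, the second highest of three measured numbers. It sits under compound 1 `COc1c(OC)c(OC(=O)C(C)(C)C)c2cc(Cl)ccc2c1OC(=O)C(C)(C)C`, which gives 6.6. It sits over compound 2 `COc1ccc2c(OC(=O)C(C)(C)C)c(OC)c(OC)c(OC(=O)C(C)(C)C)c2c1`, which gives 5.4.

Compound 4 `COc1c(OC)c(OC(=O)C(C)(C)C)c2cc(C)c(C)cc2c1OC(=O)C(C)(C)C` differs from compound 3 at one place: methyl in place of hydrogen on an aromatic carbon. That is methyl in place of hydrogen on an aromatic carbon, ortho to a methyl group.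

Among the measured compounds shown here, no measured step makes this exact swap, so the evidence is indirect. The nearest steps are swaps on an aromatic carbon. Methyl in place of chloro gave a number 0.50 log units lower from compound 1 to compound 3 (beyond the scatter), a modest step. Methyl in place of methoxy gave a number 0.70 log units higher from compound 2 to compound 3 (beyond the scatter), also modest. Methoxy in place of chloro gave a number 1.20 log units lower from compound 1 to compound 2 (beyond the scatter), a large step. All three lie beyond the scatter, so a single swap can clearly register here.

A modest rise is therefore expected, and the estimated move is a number 0.50 log units higher from compound 3 to compound 4 (beyond the scatter). Compound 4 is expected at 6.6, with an estimated range from 6.2 to 7.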

Compound 4, partition coefficient: 6.5
Compound 4: middle estimate off by 0.10 log units, on the high side, and the stated range covers the measured number.
By their numbers in this assay, from the lowest: compound 2; then compound 3; then compounds 4 and 1 (each within the scatter of the next).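

Until now, every step exchanged one group for another, and none placed a group where a hydrogen had stood. This result adds that missing kind of change: in this assay, methyl in place of hydrogen on an aromatic carbon, ortho to a methyl group, gives a number 0.40 log units higher from compound 3 to compound 4 (beyond the scatter), so this carbon of the shared core can also register a single change. Nothing shown here explains why the number moves by this amount.

The compounds leave open whether methyl would give a similar step at this carbon if the existing methyl group were absent. They also leave open how a longer chain, an amine or a carboxylic acid would read at this carbon, so this one step cannot yet be extended to other groups.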